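A few compounds are considered here, and "the series" means these few. Any claim that something is new, unique, unknown or untested is made for them only; others in the source may bear on it.

Measured so far in an ADME assay on microsomes from liver (Rattus norvegicus) for metabolic stability, with a stated time of 60 min, tested at 1 uM; a lower number here means that less of the compound is left, a higher number that more of the compound is left:
compound 1 `COc1cc(-c2cnn3cc(OC)c(-c4cc(C)no4)nc23)ccn1`: 62%
compound 2 `COc1cc(-c2cnn3cc(OC)c(C(C)(C)O)nc23)ccn1`: 92%
compound 3 `COc1cc(-c2cnn3cc(OC)c(C)nc23)ccn1`: 13%

Compound 3 stands lowest of the three, and both other compounds lie beyond the scatter from it. The next compound is compound 4 `COc1cnc2c(-c3ccnc(OC)c3)cnn2c1`, which differs from compound 3 by hydrogen in place of methyl on an aromatic carbon. This is hydrogen in place of methyl on an aromatic carbon, next to the ring nitrogen and ortho to a methoxy group.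

Among the measured compounds shown here, no measured pair has hydrogen at this place, so the available steps bear on the change only indirectly. All three steps vary the same place. The change a number 49 percentage points lower from compound 1 to compound 3 (beyond the scatter) is large, as is a number 79 percentage points lower from compound 2 to compound 3 (beyond the scatter), while a number 30 percentage points higher from compound 1 to compound 2 (beyond the scatter) is modest. The read-out therefore moves strongly with the group at this place in these compounds, but none of the steps shows how hydrogen compares with methyl. Compound 3, at 13%, leaves little room downward, so a small to modest step upward in this assay is expected, and no change beyond the scatter remains possible. The expected change is a number 11 percentage points higher from compound 3 to compound 4 (beyond the scatter). For compound 4 the estimated value is 24%, with an expected range from 8% to 48%.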

Compound 4, percent of the compound remaining: 10%
Estimate against measurement, compound 4: 14 percentage points above, and the stated range covers the measured number.
By their numbers in this assay, from the lowest: compounds 4 and 3 (each within the scatter of the next); then compound 1; then compound 2.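

In this assay, among the compounds shown here, the step of a number 3 percentage points lower from compound 3 to compound 4 (within the scatter) places hydrogen and methyl on this aromatic carbon, next to the ring nitrogen and ortho to a methoxy group, on a level that cannot be told apart, a comparison the earlier compounds did not offer. The two other groups now also have a reference with hydrogen at this place: the step of a number 82 percentage points lower from compound 2 to compound 4 (beyond the scatter) and the step of a number 52 percentage points lower from compound 1 to compound 4 (beyond the scatter) both lie far outside what separates methyl from hydrogen, so among these four compounds the higher numbers go with 1-hydroxy-1-methylethyl and 3-methyl-1,2-oxazol-5-yl, and no compound goes against this. Nothing available here accounts for any of these steps.

Open, from the compounds shown here alone, is how much of the group in compound 2 is needed at this place, for instance whether a hydroxymethyl or an ethyl already reads near compound 2 at 92% in this assay or stays near compound 3 at 13% in the same read-out. Also open, going by these compounds, is how a primary amine or a carboxylic acid at this place would read, and whether the same order holds with a chlorine in place of the methoxy group on the shared core.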